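Mirror Image of Compound 1: Expected Agonist Response

The source may hold more compounds than are shown below. What is called first, only, known or untested is meant among the compounds shown, and "the series" means these compounds.

Measured compounds:
compound 1 `CN1C[C@H]2C=C(c3cccnc3)C[C@H](C2)C1`: 19%
compound 2 `CN1CC2C=C(c3ccc(F)nc3)CC(C2)C1`: 22%
compound 3 `C1=C(c2cccnc2)C[C@H]2CNC[C@@H]1C2`: 114%

In an in vitro functional assay on SH-EP1 cells for agonist activity at Neuronal acetylcholine receptor; alpha4/beta2 (Homo sapiens), read by FLIPR and calcium flux (on this read-out lower numbers stand for smaller maximal responses and higher numbers for larger maximal responses), compound 1 gives 19%, the lowest of the three numbers. Compound 2 gives 22%, which is within the usual scatter of compound 1. Going by the values given here, the only single-place step measured is a number 95 percentage points higher from compound 1 to compound 3 (beyond the scatter), a large rise that comes with hydrogen in place of methyl on an amine nitrogen in a ring.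

Compound 4 `CN1C[C@@H]2C=C(c3cccnc3)C[C@@H](C2)C1` differs from compound 1 in this way: the two compounds have the same atoms and bonds and differ only in configuration as drawn: 2 of 2 stereo elements differ (all stereocentres are inverted: mirror images); a stereocentre at a saturated ring carbon is drawn R in compound 1 and S in compound 4; a stereocentre at a saturated ring carbon is drawn S in compound 1 and R in compound 4. No measured step concerns a change of configuration alone, so nothing shown tells how large a step to expect in this assay or in which direction. Mirror images can respond very differently, so the expectation for compound 4 is 35%, ranging from 5% to 105%. That corresponds to an expected step of a number 16 percentage points higher from compound 1 to compound 4 (beyond the scatter).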

Compound 4, largest response reached (reported as percent of maximum), in percent of the reference or control that the assay uses: 53%
Compound 4: the middle estimate sits 18 percentage points below what was measured, within the range that was stated.
By their numbers in this assay, from the lowest: compounds 1 and 2 (each within the scatter of the next); then compound 4; then compound 3.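

Turning the core into its mirror image gives a number 34 percentage points higher from compound 1 to compound 4 (beyond the scatter) while the methyl on the amine nitrogen stays in place, so the drawn configuration alone moves the maximal response. Until now, only the swap of methyl for hydrogen had shown a large step. This rise can be traced to configuration because nothing else changes: the fact that compounds 1 and 4 differ only in the configuration as drawn.

As far as these compounds go, whether the mirror image of compound 3, with hydrogen on that nitrogen, shifts the same way remains open. So does how an ethyl group on that nitrogen would behave in either configuration.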